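Swapping a dimethoxyphenyl arm for furan in a curcumin-like series

The source may hold more compounds than are shown below. What is called first, only, known or untested is meant among the compounds shown, and "the series" means these compounds.

Measured so far:
- compound 1, `COc1ccc(/C=C/C(=O)/C=C/c2ccc(OCc3cn(CCCCOc4cc(=O)oc5ccccc45)nn3)c(OC)c2)cc1OC`: "not active" (no number reported)
- compound 2, `COc1cc(/C=C/C(=O)/C=C/c2cc(OC)c(OC)c(OC)c2)ccc1OCc1cn(CCOc2cc(=O)oc3ccccc23)nn1`: 22%

In a functional assay on PC-3 cells (Homo sapiens) for inhibition, read by sulforhodamine B assay, with a stated time of 48 h, tested at 50 uM (a lower number here means less inhibition of growth, a higher number more inhibition of growth at the concentration tested), compound 1 is recorded only as "not active" (no number reported), so no single number fixes where it stands. Among the measured compounds shown here, compound 2 gives 22% in this assay, a modest figure; since no step between the two is computed, the pair shows only that neither reaches strong inhibition.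

Compound 3, `COc1cc(/C=C/C(=O)/C=C/c2ccco2)ccc1OCc1cn(CCCCOc2cc(=O)oc3ccccc23)nn1`, is not yet measured. It departs from compound 1 in one place: furan-2-yl in place of 3,4-dimethoxyphenyl on a double-bonded chain carbon bound to a double-bonded chain carbon.

For the measured compounds named here, with no measured step on record, and compound 1 itself reported as inactive, the expected movement in this assay from compound 1 to compound 3 is small, likely none beyond the scatter, and the direction cannot be read from the data. Compound 3 is therefore expected to give about 10% in this assay, in a range from 0% to 30%, with a fair chance that it too is reported as inactive.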

Compound 3, percent growth inhibition at one concentration: "not active" (no number reported)
Compound 3 has no reported number here, and the estimate cannot be compared.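

In this assay compound 1 gives "not active" (no number reported) and compound 3 gives "not active" (no number reported) so no step can be read between them. As far as these compounds go, whether furan-2-yl in place of 3,4-dimethoxyphenyl changes growth inhibition at all stays open. Nothing at hand bears on this result.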